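Trimming the amide substituent: isobutyl to ethyl

A few compounds are considered here, and "the series" means these few. Any claim that something is new, unique, unknown or untested is made for them only; others in the source may bear on it.

Measured compounds:
Compound 1 `CC[C@@H]1C(=O)N(C)c2cnc(-n3ccc4cc(C(=O)NC(C)C)ccc43)nc2N1C1CCCC1`: 17.4 nM
Compound 2 `CC[C@@H]1C(=O)N(C)c2cnc(-n3ccc4cc(C(=O)NCC(C)C)ccc43)nc2N1C1CCCC1`: 18.6 nM

Going by the values given here, in an assay for inhibition of serine/threonine-protein kinase PLK2 (Homo sapiens), read by FRET and Z'-LYTE, with a stated time of 1 h (a lower number here means a stronger inhibitor, a higher number a weaker inhibitor), compound 2 gives the higher of the two numbers, yet its only neighbour, compound 1, sits so close that the step of a 1.1-fold higher number from compound 1 to compound 2 (0.03 log units; within the scatter) carries no meaning of order. Compound 3 `CCNC(=O)c1ccc2c(ccn2-c2ncc3c(n2)N(C2CCCC2)[C@H](CC)C(=O)N3C)c1` is the next variation on the same amide, with the change (methyl in place of isopropyl on a saturated chain carbon bound to an amide-type nitrogen). Among the compounds with values here, the one measured step that bears on this position is the one from compound 1 to compound 2, which was within the scatter: replacing one small alkyl group with another on this amide nitrogen left this assay essentially unchanged. On that basis a further cut in the same chain is expected to give no step beyond the scatter, a 1.1-fold higher number from compound 2 to compound 3 (0.03 log units; within the scatter). For compound 3 the estimate in this assay is 20 nM, with a range from 8 nM to 50 nM.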

Compound 3, half-maximal inhibitory concentration: 4.88 nM
The estimate for compound 3 lay 4.1-fold (0.61 log units) above the measured number; measured number below the stated range.
By their numbers in this assay, from the lowest: compound 3; then compounds 1 and 2 (each within the scatter of the next).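

In this assay the amide substituent turns out to matter: the isobutyl-to-ethyl change gives a step beyond the scatter (a 3.8-fold lower number from compound 2 to compound 3 (0.58 log units; beyond the scatter)), and the comparison with the isopropyl amide points the same way (a 3.6-fold lower number from compound 1 to compound 3 (0.55 log units; beyond the scatter)). The swap between isopropyl and isobutyl had suggested that this nitrogen tolerated any small alkyl group without change, but the ethyl amide now stands apart from both, while those two remain within the scatter of each other. Nothing available here accounts for this difference.

The compounds shown leave open where a methyl amide, the unsubstituted amide or a straight propyl chain on this nitrogen would fall. Ethyl is also the only unbranched group among the three, so the effects of chain length and branching cannot be told apart.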